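The source may hold more compounds than are shown below. What is called first, only, known or untested is meant among the compounds shown, and "the series" means these compounds.

Measured compounds and their results in an assay on isolated protein for binding affinity to leukotriene B4 receptor 1 (Homo sapiens), tested at 1 uM; a lower number here means less inhibition, a higher number more inhibition at the concentration tested (going by the name of the read-out):
compound 1, `C=CCc1cc(C(C)=O)c(O)cc1OCCCCCC#N`, 41%;
compound 2, `C=CCc1cc(C(C)=O)c(O)cc1OCCCCCCC`, 8%;
compound 3, `C=CCCCCOc1cc(O)c(C(C)=O)cc1CC=C`, 27%.

Compound 3 stands second of the three numbers in this assay. Its nearest neighbour is compound 1, which lies higher by a number 14 percentage points lower from compound 1 to compound 3 (beyond the scatter), and its furthest is compound 2, which lies lower by a number 19 percentage points higher from compound 2 to compound 3 (beyond the scatter). Both of these gaps fall beyond the usual scatter of the measurement.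

Compound 4, `C=CCc1cc(C(C)=O)c(O)cc1OCCCCCC(C)(C)O`, is not yet measured. It differs from compound 3 by 2-hydroxy-2-methylpropyl in place of vinyl on a saturated chain carbon, four bonds along the chain from an oxygen on an aromatic ring.

Going by the values given here, two measured steps bear on this change, since both alter the same chain carbon. The step from compound 2 to compound 3 was modest and upward; the step from compound 1 to compound 3 was modest and downward. The entering group carries one hydrogen-bond donor and one hydrogen-bond acceptor, whereas the vinyl it replaces carries none, and the compound among the three with an acceptor on that chain, compound 1, gives the highest number. Among the compounds with values here, on that basis compound 4 is expected to move upward by about a number 13 percentage points higher from compound 3 to compound 4 (beyond the scatter), though no measured step covers a hydroxyl on this chain, so the expectation is loose. Compound 4 is estimated at 40%, with a range from 20% to 60%.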

Compound 4, a percentage reported as inhibition, at one concentration (the size of the read-out at that concentration, not a potency): 60%
Compound 4: the middle estimate sits 20 percentage points below what was measured, and the stated range covers the measured number.
By their numbers in this assay, from the lowest: compound 2; then compound 3; then compound 1; then compound 4.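

In this assay, 2-hydroxy-2-methylpropyl in place of vinyl on the saturated chain carbon gives a number 33 percentage points higher from compound 3 to compound 4 (beyond the scatter), so this position accepts a group with a hydrogen-bond donor and the number still rises. The nitrile no longer marks the top of the series: 1-hydroxy-1-methylethyl in place of cyano gives a number 19 percentage points higher from compound 1 to compound 4 (beyond the scatter), and the same group in place of ethyl gives a number 52 percentage points higher from compound 2 to compound 4 (beyond the scatter), the widest step among these compounds. Nothing in hand explains why this group gives the highest number.

The compounds shown do not separate the hydroxyl from the two methyl groups on the same carbon, a question that a chain ending in a primary alcohol, a carboxylic acid or an amine would bear on. Going by these compounds, whether the rise holds on a shorter or longer chain also stays open.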